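This account rests on a few compounds, and the source may have more. Where it says the series, first, only, none or still open, it means among the compounds named here.

Compound 1 `CSc1ccc2nc(C)cc(OCC(=O)Nc3cc(C)cc(C)c3)c2c1` is one of two compounds with a result in a toxicity assay on HepG2 cells (Homo sapiens) for inhibition, read by CellTiter-Glo, with a stated time of 48 h; a higher number here means a weaker inhibitor, a lower number a stronger inhibitor. In this assay compound 1 reaches only the assay limit, giving > 100000 nM, which is a limit and not a measured number. The other measured compound, compound 2 `COc1ccc2c(OCC(=O)Nc3cc(C)cc(C)c3)cc(C)nc2c1`, shares the core and the amide side chain but carries a methoxy group where compound 1 carries methylsulfanyl; in this assay compound 2 gives 50100 nM. Among the compounds with values here, no step between the two measured compounds is counted here, so the two values are stated and nothing more is drawn from the pair. The single note on the measured values is the limit of > 100000 nM in this assay, at which 1 of the 2 values shown sits, which places compound 1 at the limit. Compound 3 `Cc1cc(C)cc(NC(=O)COc2cc(C)nc3ccc(C)cc23)c1` has not yet been tested in this assay. It differs from compound 1 by methyl in place of methylsulfanyl on an aromatic carbon. Given that compound 1 sits at a limit of > 100000 nM, the step from compound 1 to compound 3 is expected to stay within the usual scatter, with no clear direction, as a number no higher from compound 1 to compound 3 (the limit leaves the size open) expresses. Compound 3 is therefore estimated at 100000 nM, within a range of 30000 nM to 300000 nM, and it may well return only a limit again.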

Compound 3, half-maximal inhibitory concentration: 15900 nM
The estimate for compound 3 lay 6.3-fold (0.80 log units) above the measured number; the measured number lies below the stated range.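

In this assay, methyl in place of methylsulfanyl on an aromatic carbon gives an at least 6.2-fold lower number from compound 1 to compound 3 (0.79 log units; beyond the scatter), which shows that the number in this assay responds to the group at this place on the shared core. Within the data shown here, until this result no step could be read at all, and the earlier compounds gave no sign of how a change at this carbon would register; now the loss of the sulfur, leaving a single heavy atom where there were two, goes with stronger inhibition. The true size of the step stays open at its upper end because compound 1 gives a limit and not a measured number: the limit of > 100000 nM in this assay, at which 1 of the 3 values shown sits.

A single pair does not separate the removal of the sulfur from the drop in heavy atoms, nor does it show whether the step would hold with a different amide side chain. From the compounds shown here alone, how an ethyl group, a chlorine atom or an amine on the same aromatic carbon would read in this assay remains open, and with it whether any trend runs across this position.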